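Swapping the aryl group on sulfur in compound 2

The source may report more compounds than this note shows. Statements on the series, on what has been measured and on what is new or still open speak of the compounds shown alone.

Compound 1, `O=[N+]([O-])c1cccc2c1CCN(c1ncnc3c1ncn3[C@@H]1O[C@H](CO)[C@@H](O)[C@H]1O)C2`: 3020 nM
Compound 2, `Cc1cc(C)c(SCc2ncnc3c2ncn3[C@@H]2O[C@H](CO)[C@@H](O)[C@H]2O)c(C)c1`: 33100 nM

In an assay on isolated protein for binding affinity to Equilibrative nucleoside transporter 1 (Homo sapiens) (a higher number here means a weaker inhibitor, a lower number a stronger inhibitor), compound 2 gives 33100 nM, the higher of the two numbers measured; its nearest neighbour, compound 1, gives 3020 nM, a gap that lies beyond the usual scatter. Compound 3, `OC[C@H]1O[C@@H](n2cnc3c(CSc4cccc(I)c4)ncnc32)[C@H](O)[C@@H]1O`, keeps the core of compound 2 and differs only where the aryl group sits: 3-iodophenyl in place of 2,4,6-trimethylphenyl on a sulfur. Among the compounds with values here, no measured pair shows this kind of change, so its effect can only be guessed from the two numbers at hand. Within the data shown here, since the only other measured compound gives a lower number, a small move in that direction is expected, with the step of a 2.2-fold lower number from compound 2 to compound 3 (0.34 log units; beyond the scatter) most likely within or just beyond the scatter. Compound 3 is therefore estimated at 15000 nM, with a range from 4000 nM to 60000 nM.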

Compound 3, half-maximal inhibitory concentration: 245 nM
Beside the measured number, compound 3's estimate is 61-fold (1.79 log units) above it; the measured number lies below the stated range.
By their numbers in this assay, from the lowest: compound 3; then compound 1; then compound 2.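

Within the data shown here, the aryl group on the sulfur is the first place where a single change can be read, and in this assay it proves far from neutral: 3-iodophenyl in place of 2,4,6-trimethylphenyl gives a 140-fold lower number from compound 2 to compound 3 (2.13 log units; beyond the scatter) on an otherwise unchanged compound. Both groups are one six-membered aromatic ring of carbon only, with no hydrogen-bond donors or acceptors and no net charge, so a change confined to what that ring carries is enough for a step of this size. Nothing measured here says why the number falls so far.

From the compounds shown here alone, whether the step belongs to the iodine or to the loss of the methyl groups stays open, and a plain phenyl or a 3-bromophenyl on the same sulfur would separate the two. Also open, going by these compounds, is what the sulfur itself contributes, which an oxygen or an amine nitrogen in its place would test.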